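The source may report more compounds than this note shows. Statements on the series, on what has been measured and on what is new or still open speak of the compounds shown alone.

Measured compounds in an ADME assay on HEK293 cells (Homo sapiens) for cytotoxicity, read by resazurin assay, with a stated time of 48 h; on this read-out lower numbers stand for higher toxicity in this test and higher numbers for lower toxicity in this test:
Compound 1 `O=S(=O)(Nc1ccc(-c2nc3ccccc3o2)cc1)c1ccccc1C(F)(F)F` gives > 100000 nM, a limit of this assay.
Compound 2 `Cc1ccccc1S(=O)(=O)Nc1ccc(-c2nc3ccccc3o2)cc1` gives > 100000 nM, also a limit.
Compound 3 `O=S(=O)(Nc1ccc2oc(-c3ccccc3)nc2c1)c1cccc(F)c1` gives 68000 nM.

Compound 2 stands at the limit of > 100000 nM in this assay, at which 2 of the 3 values shown sit, so only a limit and no number is known for it. For the measured compounds named here, the one measured step that touches it, a step that the two limits leave unreadable from compound 1 to compound 2, cannot be read in size. Compound 4 `O=S(=O)(Nc1ccc(-c2nc3ccccc3o2)cc1)c1cccc(F)c1` differs from compound 2 by 3-fluorophenyl in place of 2-methylphenyl on a sulfonyl sulfur. Going by the values given here, compound 3 carries the same 3-fluorophenyl on a different core and gives a number rather than a limit, but no step between the two cores is measured, so no measured step bears directly on the change. No shift beyond the scatter is expected, a number no higher from compound 2 to compound 4 (the limit leaves the size open). For compound 4 a value near 100000 nM is estimated, within 40000 nM to 300000 nM.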

Compound 4, half-maximal cytotoxic concentration: > 100000 nM
Compound 4 ended at the assay's limit; the forecaster's own chance of this, stated with the estimate: 50%; the middle value lies on the limit itself.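

Compound 2 and compound 4 both end at a limit and not at a number, so no step can be read between them: the limit of > 100000 nM in this assay, at which 3 of the 4 values shown sit.

What the compounds shown leave open is how far 3-fluorophenyl in place of 2-methylphenyl shifts the value on the shared core.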